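The compounds below may be only part of what the source reports. "The series", "measured", "known", "first", "only" and "open" are said of these compounds alone.

Measured so far:
- compound 1 `CN(C(=O)NC(=O)c1ccccc1F)c1nc(C(F)(F)F)c(C(=O)N/N=C/c2cccc(C(F)(F)F)c2)s1`: 16.3 ug/mL
- compound 2 `CN(C(=O)NC(=O)c1ccccc1F)c1nc(C(F)(F)F)c(C(=O)N/N=C/c2cc(C(F)(F)F)cc(C(F)(F)F)c2)s1`: 4.23 ug/mL
- compound 3 `CN(C(=O)NC(=O)c1ccc(C(F)(F)F)cc1)c1nc(C(F)(F)F)c(C(=O)N/N=C/c2cccc(C(F)(F)F)c2)s1`: 1.84 ug/mL

All three were tested in a functional assay on BCG823 cells (Homo sapiens) for inhibition, read by MTT assay, with a stated time of 72 h; a higher number here means a weaker inhibitor, a lower number a stronger inhibitor. Compound 1 gives the highest number of the three, so it is the weakest inhibitor shown: there is a 3.9-fold lower number from compound 1 to compound 2 (0.59 log units; beyond the scatter) and an 8.9-fold lower number from compound 1 to compound 3 (0.95 log units; beyond the scatter), both beyond the scatter.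

Compound 4 `CNc1nc(C(F)(F)F)c(C(=O)N/N=C/c2cccc(C(F)(F)F)c2)s1` is not yet measured. It differs from compound 1 in one place: hydrogen in place of ((2-fluorophenyl)carbonyl)carbamoyl on a nitrogen on an aromatic ring. This is a far larger change than either measured step, which only swapped substituents on the aryl rings while keeping the ((2-fluorophenyl)carbonyl)carbamoyl group in place. Within the data shown here, no measured pair therefore bears directly on removing that group. The only hint is that altering the aryl ring within it gave an 8.9-fold lower number from compound 1 to compound 3 (0.95 log units; beyond the scatter), so the group is not inert to the number. Removing it entirely is expected to move compound 4 toward a higher number than compound 1, by a 1.8-fold higher number from compound 1 to compound 4 (0.26 log units; within the scatter), with wide uncertainty.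

Compound 4 is estimated at 30 ug/mL, between 8 ug/mL and 100 ug/mL.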

Compound 4, half-maximal inhibitory concentration: > 100 ug/mL
Compound 4 was reported as a limit; the forecaster's own chance of this, stated with the estimate: 30%; middle value at least 3.3-fold (0.52 log units) from the limit.
By their numbers in this assay, from the lowest: compound 3; then compound 2; then compound 1. At a limit, above all of these: compound 4.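

In this assay, compound 4 gives > 100 ug/mL, which is a limit of the assay and not a number: the limit of > 100 ug/mL in this assay, at which 1 of the 4 values shown sits.

Replacing the ((2-fluorophenyl)carbonyl)carbamoyl group with hydrogen on this nitrogen gives an at least 6.1-fold higher number from compound 1 to compound 4 (0.78 log units; beyond the scatter), so the inhibitor becomes clearly weaker when the group is lost. The earlier steps shown here only changed substituents on aryl rings while this group stayed in place, so they could not show what its complete removal does to the number.

From the compounds shown here alone, because compound 4 is reported only as a limit, the full size of this step stays unknown. Also open, going by these compounds, is whether a smaller piece on the same nitrogen, such as an acetyl group or a plain carbamoyl group, would keep the number nearer that of compound 1.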